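Chloro substitution on fused cores in HCT-116 growth inhibition

A few compounds are considered here, and "the series" means these few. Any claim that something is new, unique, unknown or untested is made for them only; others in the source may bear on it.

Measured compounds:
Compound 1, `ClCc1ccccc1Cn1cnc2c(Cl)nc(Cl)nc21`: 190 nM
Compound 2, `ClCc1ccccc1Cn1cnc2c(Cl)ncnc21`: 1900 nM
Compound 3, `ClCc1ccccc1Cn1cnc2ncnc(Cl)c21`: 1510 nM

All three were tested in a functional assay on HCT-116 cells (Homo sapiens) for cytotoxicity, read by sulforhodamine B assay, with a stated time of 48 h; on this read-out lower numbers stand for stronger inhibition of growth and higher numbers for weaker inhibition of growth. Compound 1 differs from compound 2 by chloro in place of hydrogen on an aromatic carbon, and this produced a 10-fold lower number from compound 2 to compound 1 (1.00 log units; beyond the scatter). Compound 3 has the same atoms as compound 2 joined differently; the difference between the two cores is not broken down here. In this assay compound 3 and compound 2 give numbers that lie within the usual scatter of each other, so no order between them is claimed.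

Compound 4, `ClCc1ccccc1Cn1cnc2nc(Cl)nc(Cl)c21`, has not yet been measured. It differs from compound 3 by chloro in place of hydrogen on an aromatic carbon, the same change as that from compound 2 to compound 1. Within the data shown here, compound 4 is expected to give about 200 nM in this assay, because a 10-fold lower number from compound 2 to compound 1 (1.00 log units; beyond the scatter) was observed for the one earlier instance of this change. The expected step is a 7.6-fold lower number from compound 3 to compound 4 (0.88 log units; beyond the scatter), and since it rests on a single pair on a differently joined core, compound 4 is estimated to fall between 70 nM and 700 nM.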

Compound 4, concentration for 50% growth inhibition: 1860 nM
Estimate against measurement, compound 4: 9.3-fold (0.97 log units) below; measured number outside the range, above it.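

In this assay the change gave a 1.2-fold higher number from compound 3 to compound 4 (0.09 log units; within the scatter) and so did not repeat on this core. Set beside the earlier instance, the step clearly depends on the core that carries it: the same change on two cores in this assay, a 10-fold lower number (1.00 log units; beyond the scatter) from compound 2 to compound 1 and a 1.2-fold higher number (0.09 log units; within the scatter) from compound 3 to compound 4, 12-fold (1.09 log units) apart, beyond the scatter of two such steps. This shows that, in this series, the effect seen in going to compound 1 cannot simply be carried across to the differently joined core of compound 4, but with one pair on each core it does not show why the two cores part, nor whether any other group would part them in the same way.

The compounds shown leave open how an amine, a methoxy group or a longer chain in place of the chloro group would behave on either core in this assay. They also leave open whether the difference between the cores would survive if the chloromethyl group, which all of them share, gave way to a hydroxymethyl group.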